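From Nitro to Pyridin-4-yl in Cell Tolerance

A few compounds are considered here, and "the series" means these few. Any claim that something is new, unique, unknown or untested is made for them only; others in the source may bear on it.

In an ADME assay on L6 cells (Rattus norvegicus) for cytotoxicity, read by fluorescence and resazurin assay, with a stated time of 72 h (a lower number here means that less compound is tolerated, a higher number that more compound is tolerated), compound 1 (`O=[N+]([O-])c1ccc(-c2c[nH]cc2C(c2ccc(Cl)cc2Cl)n2ccnc2)cc1`) gives 16900 nM, which places it at the upper end of the three measured numbers. Compound 3 (`FC(F)(F)c1ccc(-c2c[nH]cc2C(c2ccc(Cl)cc2Cl)n2ccnc2)cc1`) gives 9400 nM, and compound 2 (`CSc1ccc(-c2c[nH]cc2C(c2ccc(Cl)cc2Cl)n2ccnc2)cc1`) gives 7220 nM. Compound 4 (`Clc1ccc(C(c2c[nH]cc2-c2ccc(-c3ccncc3)cc2)n2ccnc2)c(Cl)c1`) has not yet been measured. It differs from compound 1 as follows: pyridin-4-yl in place of nitro on an aromatic carbon. The change lies on an aromatic carbon, para to a large group, and the measured compounds vary at that same place. Among the measured compounds shown here, three steps bear on it: a 2.3-fold lower number from compound 1 to compound 2 (0.37 log units; beyond the scatter), a 1.8-fold lower number from compound 1 to compound 3 (0.25 log units; within the scatter) and a 1.3-fold higher number from compound 2 to compound 3 (0.11 log units; within the scatter). For the measured compounds named here, neither replacement of nitro gave a higher number, but no measured step brings in a ring, so these steps offer only a loose guide. The estimated outcome is a 2.4-fold lower number from compound 1 to compound 4 (0.38 log units; beyond the scatter), a modest move toward a lower number in this assay. Compound 4 is therefore expected at 7000 nM, with an estimated range from 2500 nM to 20000 nM.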

Compound 4, half-maximal cytotoxic concentration: 15500 nM
Compound 4: the middle estimate sits 2.2-fold (0.35 log units) below what was measured; the measured number falls inside the stated range.
By their numbers in this assay, from the lowest: compounds 2, 3, 4 and 1 (each within the scatter of the next, the first and the last beyond it).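

In this assay the position accepts pyridin-4-yl, a ring with more heavy atoms than nitro, with a 1.1-fold lower number from compound 1 to compound 4 (0.04 log units; within the scatter) and so no difference that can be told from the usual scatter. The same group shows a 1.6-fold higher number from compound 3 to compound 4 (0.22 log units; within the scatter) and also a 2.1-fold higher number from compound 2 to compound 4 (0.33 log units; beyond the scatter) here, so among the groups at this place only methylsulfanyl stands apart from it, and the first ring seen here does not lower the number as the loose guide from the smaller groups suggested. Nothing available accounts for this result.

The compounds shown leave open whether the ring nitrogen of pyridin-4-yl matters, which a plain phenyl or a pyridin-3-yl group at this place would address. They also leave open how an amine or a carboxylic acid on this aromatic carbon would fare.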